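The compounds below may be only part of what the source reports. "The series", "measured", "known", "first", "only" and "open" are said of these compounds alone.

Measured so far:
compound 1 `CCC(O)c1cn(CCNc2nonc2/C(=N/O)Nc2ccc(F)c(Br)c2)nn1` — 73 nM
compound 2 `CCC(C)(O)c1cn(CCNc2nonc2/C(=N/O)Nc2ccc(F)c(Br)c2)nn1` — 53 nM

Going by the values given here, in an assay on isolated protein for inhibition of Indoleamine 2,3-dioxygenase 1 (Homo sapiens) (on this read-out higher numbers stand for weaker inhibition and lower numbers for stronger inhibition), compound 2 gives the lowest of the two numbers recorded, but the only neighbour, compound 1, lies close: a 1.4-fold lower number from compound 1 to compound 2 (0.14 log units; within the scatter). The two cannot be ranked against each other.

Compound 3 `CC(C)(OCCO)c1cn(CCNc2nonc2/C(=N/O)Nc2ccc(F)c(Br)c2)nn1` is the next candidate. Its change from compound 2 is 1-(2-hydroxyethoxy)-1-methylethyl in place of 1-hydroxy-1-methylpropyl on an aromatic carbon.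

Among the compounds with values here, only one measured step is available, and it tells a different story: it added a methyl to a saturated chain carbon and moved the number by a 1.4-fold lower number from compound 1 to compound 2 (0.14 log units; within the scatter), a shift inside the scatter. Within the data shown here, the present change instead reshapes the side chain and adds an ether oxygen, for which no measured pair exists. Among the measured compounds shown here, since the one known change at this position stayed within the scatter, the expectation for compound 3 is no step beyond the scatter, with wide uncertainty: a 1.3-fold higher number from compound 2 to compound 3 (0.12 log units; within the scatter), giving an estimate of 70 nM, spanning 30 nM to 170 nM.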

Compound 3, half-maximal inhibitory concentration: 176 nM
Beside the measured number, compound 3's estimate is 2.5-fold (0.40 log units) below it; the measured number lies above the stated range.
By their numbers in this assay, from the lowest: compounds 2 and 1 (each within the scatter of the next); then compound 3.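

In this assay, going by these compounds alone, putting 1-(2-hydroxyethoxy)-1-methylethyl in place of 1-hydroxy-1-methylpropyl gives a 3.3-fold higher number from compound 2 to compound 3 (0.52 log units; beyond the scatter), the first step at this position that lies beyond the scatter. Putting the same group in place of 1-hydroxypropyl gives a 2.4-fold higher number from compound 1 to compound 3 (0.38 log units; beyond the scatter), so this aromatic carbon does respond to what it carries, and here the response is weaker inhibition against both earlier compounds. Nothing available accounts for this loss.

The change adds heavy atoms and an ether oxygen together, and the compounds shown do not separate these two parts of it. Also open, from the compounds shown here alone, is how a smaller ether such as 1-methoxy-1-methylethyl, or an amine on the same chain, would read at this position.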